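Swapping phenyl for methyl on a tetrazole: cytotoxicity shift

The compounds below may be only part of what the source reports. "The series", "measured", "known", "first", "only" and "open" are said of these compounds alone.

Compound 1 `O=C(CSc1nnnn1-c1ccccc1)N/N=c1/scc(-c2ccc(Br)cc2)n1-c1ccccc1` is the starting point of this set. In an ADME assay on NIH3T3 cells (Mus musculus) for cytotoxicity, read by MTT assay, with a stated time of 24 h (a higher number here means a weaker inhibitor, a lower number a stronger inhibitor), compound 1 gives 433 ug/mL. Compound 2 `Cn1nnnc1SCC(=O)N/N=c1/scc(-c2ccc(Br)cc2)n1-c1ccccc1` differs from it in one place: methyl in place of phenyl on an aromatic nitrogen. With that change the number drops, a 22-fold lower number from compound 1 to compound 2 (1.35 log units; beyond the scatter).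

Compound 3 `O=C(CSc1nnnn1-c1ccccc1)N/N=c1/scc(-c2ccccc2)n1-c1ccccc1` shares the framework of compound 1 but carries a different core, the difference being (hydrogen in place of bromo on an aromatic carbon). In this assay compound 3 gives 417 ug/mL, and the step of a 1.0-fold lower number from compound 1 to compound 3 (0.02 log units; within the scatter) shows that removing bromo on its own leaves the reading essentially where it was. Compound 2, by comparison, gives 19.3 ug/mL in this assay.

Compound 4 `Cn1nnnc1SCC(=O)N/N=c1/scc(-c2ccccc2)n1-c1ccccc1` has not yet been measured. It stands to compound 3 as compound 2 stands to compound 1: methyl in place of phenyl on an aromatic nitrogen. The place lines of the two changes agree word for word, so this is the same change made on a core that differs only by the bromo-to-hydrogen exchange, which itself moved nothing beyond the usual scatter.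

Because the earlier step of a 22-fold lower number from compound 1 to compound 2 (1.35 log units; beyond the scatter) was large and because the core change a 1.0-fold lower number from compound 1 to compound 3 (0.02 log units; within the scatter) was negligible, compound 4 is expected to follow the same pattern, with a step of about a 21-fold lower number from compound 3 to compound 4 (1.32 log units; beyond the scatter) in this assay. Compound 4 is therefore estimated at 20 ug/mL in this assay, most likely between 8 ug/mL and 60 ug/mL. This rests on one pair only, compound 1 and compound 2, so the expectation is tentative.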

Compound 4, half-maximal inhibitory concentration: 173 ug/mL
Estimate against measurement, compound 4: 8.7-fold (0.94 log units) below; the measured number lies above the stated range.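

In this assay, methyl in place of phenyl on the aromatic nitrogen still lowers the number on the core without bromo, but the step shrinks to a 2.4-fold lower number from compound 3 to compound 4 (0.38 log units; beyond the scatter), so the direction of the change carries over from one core to the other while its size does not: the same change on two cores in this assay, a 22-fold lower number (1.35 log units; beyond the scatter) from compound 1 to compound 2 and a 2.4-fold lower number (0.38 log units; beyond the scatter) from compound 3 to compound 4, 9.3-fold (0.97 log units) apart, beyond the scatter of two such steps

Seen from the other side, hydrogen in place of bromo does nothing beyond the scatter when phenyl sits on the nitrogen, yet it gives a 9.0-fold higher number from compound 2 to compound 4 (0.95 log units; beyond the scatter) when methyl sits there, so the two changes cannot be treated as adding up independently: the same change on two cores in this assay, a 1.0-fold lower number (0.02 log units; within the scatter) from compound 1 to compound 3 and a 9.0-fold higher number (0.95 log units; beyond the scatter) from compound 2 to compound 4, 9.3-fold (0.97 log units) apart, beyond the scatter of two such steps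

These numbers show that the effect of one change depends on the other, but they do not show why, and two pairs of compounds cannot say how the change would behave on any further core.

The compounds shown carry only phenyl or methyl on that nitrogen and only bromo or hydrogen on the aromatic carbon. Going by these compounds, it remains open whether an ethyl group or a longer chain on the nitrogen would behave more like methyl or like phenyl, and whether chloro or methoxy in place of bromo would combine with methyl as bromo does.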